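Lengthening the Linker Chain: Expected Cytotoxicity in Rat Cells

A few compounds are considered here, and "the series" means these few. Any claim that something is new, unique, unknown or untested is made for them only; others in the source may bear on it.

Measured so far:
Compound 1 `CC(C)NC(=N)c1ccc2oc(-c3cccc(OCCCCOc4ccccc4)c3)cc2c1`: 36500 nM
Compound 2 `c1ccc(OCCCCOc2cccc(-c3cc4cc(C5=NCCN5)ccc4o3)c2)cc1`: 9500 nM

Among the measured compounds shown here, both compounds have been tested in an ADME assay on L6 cells (Rattus norvegicus) for cytotoxicity, read by resazurin assay, with a stated time of 70 h; on this read-out higher numbers stand for weaker inhibition and lower numbers for stronger inhibition. Compound 1 gives 36500 nM, and compound 2 gives 9500 nM. Among the two numbers, compound 1 has the higher one, so on this read-out it is the weaker inhibitor of cell growth; the only step in hand runs a 3.8-fold lower number from compound 1 to compound 2 (0.58 log units; beyond the scatter), and it swaps an open-chain group for a small ring on the shared core.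

Compound 3 `CC(C)NC(=N)c1ccc2oc(-c3cccc(OCCCCCOc4ccccc4)c3)cc2c1` keeps everything in compound 1 except the chain that joins the two aromatic parts: phenoxymethyl in place of phenoxy on a saturated chain carbon, four bonds along the chain from an oxygen on an aromatic ring. For the measured compounds named here, no measured pair shows a change of this kind. Going by the values given here, the single measured step concerns a different part of the molecule and says nothing about the length of the linker. With no guide in the data, a step no larger than the usual scatter is expected, in either direction, which means an expected no change at the digits printed from compound 1 to compound 3 (within the scatter). Compound 3 is therefore estimated at 36500 nM, with a range from 15000 nM to 85000 nM.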

Compound 3, half-maximal inhibitory concentration: 10100 nM
Compound 3: the middle estimate sits 3.6-fold (0.56 log units) above what was measured; measured number outside the range, below it.
By their numbers in this assay, from the lowest: compounds 2 and 3 (each within the scatter of the next); then compound 1.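

In this assay, replacing phenoxy with phenoxymethyl on a saturated chain carbon, four bonds along the chain from an oxygen on an aromatic ring, gives a 3.6-fold lower number from compound 1 to compound 3 (0.56 log units; beyond the scatter), showing that this read-out responds to the linker chain as well as to the group changed in the earlier step. Since a lower number stands for stronger inhibition here, this modest change moves compound 3 towards stronger inhibition of the rat cells than compound 1, even though the groups that leave and enter differ only by the added chain carbon. No measurement available here bears on why a change this small in the chain shifts the number.

As far as these compounds go, a single step does not make a trend, so it remains open whether the number keeps falling with 2-phenoxyethyl, 3-phenoxypropyl or 4-phenoxybutyl in the same place, or whether it would rise again along that series. Also open, from the compounds shown here alone, is whether the same change has a similar effect on the core of compound 2, and what an amine or a carboxylic acid in place of phenoxy would do to the number.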